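This account rests on a few compounds, and the source may have more. Where it says the series, first, only, none or still open, it means among the compounds named here.

Measured so far in a functional assay on A549 cells (Homo sapiens) for inhibition, read by CCK-8 assay, with a stated time of 72 h, tested at 1 uM; a lower number here means less inhibition of growth, a higher number more inhibition of growth at the concentration tested:
compound 1 `CN(C)C(=O)c1cc2cnc(Nc3ccc(NC(=O)C4(C(=O)Nc5cccc(Cl)c5)CC4)cc3)nc2n1C1CCCC1`: 8.3%
compound 2 `CN(C)C(=O)c1cc2cnc(Nc3ccc(NC(=O)C4(C(=O)Nc5ccc(Br)cc5)CC4)cc3)nc2n1C1CCCC1`: -6.6%
compound 3 `Nc1ccc(NC(=O)C2(C(=O)Nc3ccc(F)cc3)CC2)cc1F`: 16.3%

Compound 1 stands second of the three numbers. Its gap to compound 3 lies within the scatter, so no order between those two is claimed. Its gap to compound 2 is beyond the scatter: a number 14.9 percentage points lower from compound 1 to compound 2 (beyond the scatter).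

Compound 4 `CN(C)C(=O)c1cc2cnc(Nc3ccc(NC(=O)C4(C(=O)Nc5ccc(C(F)(F)F)cc5)CC4)cc3)nc2n1C1CCCC1` is not yet measured. It differs from compound 1 in one place: 4-(trifluoromethyl)phenyl in place of 3-chlorophenyl on an amide-type nitrogen. Compound 4 shares the core of compound 1 and compound 2 unchanged.

Going by the values given here, only one measured step bears on this change, the one in which a 4-bromophenyl entered in place of the same 3-chlorophenyl on the same amide-type nitrogen, and it read a number 14.9 percentage points lower from compound 1 to compound 2 (beyond the scatter), a modest lowering. Among the compounds with values here, no measured pair sets a 4-(trifluoromethyl)phenyl against either a 4-bromophenyl or a 3-chlorophenyl, so the expectation rests on that single step and on compound 1 itself. The expected step in this assay is a number 5.3 percentage points lower from compound 1 to compound 4 (within the scatter), a small lowering or nothing beyond the scatter.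

The estimate for compound 4 in this assay is 3%, with an expected range from -12% to 18%.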

Compound 4, percent growth inhibition at one concentration: -25.3%
Compound 4: middle estimate off by 28.3 percentage points, on the high side; the measured number lies below the stated range.
By their numbers in this assay, from the lowest: compound 4; then compound 2; then compounds 1 and 3 (each within the scatter of the next).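

In this assay, the group on the amide-type nitrogen proves able to shift the number far more than the first step suggested: 4-(trifluoromethyl)phenyl in place of 3-chlorophenyl gives a number 33.6 percentage points lower from compound 1 to compound 4 (beyond the scatter), a large step, while 4-bromophenyl gave a number 14.9 percentage points lower from compound 1 to compound 2 (beyond the scatter), a modest one. Trifluoromethyl in place of bromo on an aromatic carbon also gives a number 18.7 percentage points lower from compound 2 to compound 4 (beyond the scatter), so the identity of this substituent alone moves the number beyond the scatter, and the values of compound 2 at -6.6% and compound 4 at -25.3% both lie below zero, showing no growth inhibition at the concentration tested. No measurement available here accounts for the size or direction of these steps.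

The compounds shown leave open how much of the lowering follows the group and how much its place on the ring, a question that 4-chlorophenyl and 3-(trifluoromethyl)phenyl on this nitrogen would separate. Also open, on these data alone, is whether an amine or a carboxylic acid on this phenyl ring would raise the number above that of compound 1, and compound 3, which differs from the others in more than one place, cannot settle either question.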